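Methylsulfonyl step in a series held at the limit

The source may report more compounds than this note shows. Statements on the series, on what has been measured and on what is new or still open speak of the compounds shown alone.

Measured in an in vitro ADME assay on microsomes from liver (Simiiformes); a higher number here means that the compound lasts longer, a lower number that the compound disappears faster:
- compound 1 `CCOCc1cc(CCCOc2c(C)cc(-c3noc(C(F)(F)F)n3)cc2C)on1`: > 2.5 h
- compound 2 `Cc1cc(-c2noc(C(F)(F)F)n2)cc(C)c1OCCCc1cc(C[S+](C)[O-])no1`: > 2.5 h

Compound 2 stands at > 2.5 h, which is a limit of the assay and not a number. Compound 3 `Cc1cc(-c2noc(C(F)(F)F)n2)cc(C)c1OCCCc1cc(CS(C)(=O)=O)no1` is not yet measured. Its change is a group of 4 heavy atoms (1 carbon, 2 oxygen, 1 sulfur; no ring) in place of a group of 3 heavy atoms (1 carbon, 1 oxygen, 1 sulfur; no ring), on a saturated chain carbon bound to an aromatic carbon, with methylsulfonyl entering on a saturated chain carbon bound to an aromatic carbon. Among the compounds with values here, the one measured step that bears on this is a step that the two limits leave unreadable from compound 1 to compound 2, so no size carries over. In this assay the expected step that the limit leaves unreadable from compound 2 to compound 3 is therefore none beyond the scatter. For compound 3 the estimate is 3 h, with an expected range of 1.5 h to 6 h.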

Compound 3, half-life: > 2.5 h
Compound 3 ended at the assay's limit; the forecaster's own chance of this, stated with the estimate: 70%; the middle value does not contradict the limit.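

In this assay no step can be read among compound 1, compound 2 and compound 3, because all three stand at one limit of the assay: the limit of > 2.5 h in this assay, at which 3 of the 3 values shown sit.

From the compounds shown here alone, how far the half-life of each compound lies past that limit stays open.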